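The Same Ring Swap Tried on a Second Core

This account rests on a few compounds, and the source may have more. Where it says the series, first, only, none or still open, it means among the compounds named here.

Compound 1 `Cc1noc(C)c1-c1cnc(N)c(Oc2ccc(C(=O)Nc3cccc(Cl)c3)cc2)n1`: 1340 nM
Compound 2 `Cn1cc(-c2cnc(N)c(Oc3ccc(C(=O)Nc4cccc(Cl)c4)cc3)n2)cn1`: 4460 nM
Compound 3 `Cc1noc(C)c1-c1cnc(N)c(Sc2ccc(C(=O)Nc3ccc(Cl)cc3)cc2)n1`: 38400 nM

These three compounds were measured in a functional assay on HeLa cells (Homo sapiens) for inhibition, read by MTT assay, with a stated time of 72 h; on this read-out higher numbers stand for weaker inhibition and lower numbers for stronger inhibition. Compound 2 differs from compound 1 in one place, (1-methyl-1H-pyrazol-4-yl in place of 3,5-dimethyl-1,2-oxazol-4-yl on an aromatic carbon), and that change gave a 3.3-fold higher number from compound 1 to compound 2 (0.52 log units; beyond the scatter). Compound 3 stands highest of the three; how its core differs from the core of compound 1 is not broken down here. Compound 4 `Cn1cc(-c2cnc(N)c(Sc3ccc(C(=O)Nc4ccc(Cl)cc4)cc3)n2)cn1` has not yet been measured. It is made from compound 3 by 1-methyl-1H-pyrazol-4-yl in place of 3,5-dimethyl-1,2-oxazol-4-yl on an aromatic carbon, the same change, at the same place, as from compound 1 to compound 2. Among the compounds with values here, because the only measured instance of this change gave a 3.3-fold higher number from compound 1 to compound 2 (0.52 log units; beyond the scatter), compound 4 is expected to sit higher than compound 3, by an estimated 2.9-fold higher number from compound 3 to compound 4 (0.46 log units; beyond the scatter). Compound 4 is therefore expected to give about 110000 nM, between 35000 nM and 350000 nM. This expectation rests on a single pair, and so high a number may come back from this assay only as a limit.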

Compound 4, half-maximal inhibitory concentration: 42700 nM
Compound 4: middle estimate off by 2.6-fold (0.41 log units), on the high side; measured number inside the range.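

In this assay, putting 1-methyl-1H-pyrazol-4-yl in place of 3,5-dimethyl-1,2-oxazol-4-yl on the second core gave a 1.1-fold higher number from compound 3 to compound 4 (0.05 log units; within the scatter), which leaves the two compounds level. The step therefore did not carry over in size from one core to the other: the same change on two cores in this assay, a 3.3-fold higher number (0.52 log units; beyond the scatter) from compound 1 to compound 2 and a 1.1-fold higher number (0.05 log units; within the scatter) from compound 3 to compound 4, 3.0-fold (0.48 log units) apart, beyond the scatter of two such steps

This shows that, across these two pairs, the size of the step depends on the core, but it does not show which of the differences between compound 1 and compound 3 sets the gap. The compounds shown leave open how other groups in this place, such as a pyridine or a morpholine, would behave on either core. They also leave open whether a fluorine or a methoxy in place of the chlorine would alter the step.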